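Thioamide to Oxopyrrolidine Amide at the Proline Carbonyl

The source may report more compounds than this note shows. Statements on the series, on what has been measured and on what is new or still open speak of the compounds shown alone.

Measured compounds:
compound 1, `Cc1cc(C(=O)N2CCCCc3ccccc32)ccc1CNC(=O)N1CCC[C@H]1C(=O)OC(C)(C)C`: 390 nM
compound 2, `Cc1cc(C(=O)N2CCCCc3ccccc32)ccc1CNC(=O)N1CCC[C@H]1C(=S)N(C)C`: 3.2 nM

In a functional assay on HEK293 cells for agonist activity at Vasopressin V2 receptor (Homo sapiens), read by a luciferase reporter and cAMP accumulation (a higher number here means that more compound is needed for the effect, a lower number that less compound is needed), compound 2 stands lowest of the two numbers shown; its only neighbour is compound 1, and the step of a 120-fold lower number from compound 1 to compound 2 (2.09 log units; beyond the scatter) is large and well beyond the scatter. Compound 3, `Cc1cc(C(=O)N2CCCCc3ccccc32)ccc1CNC(=O)N1CC(=O)C[C@H]1C(=O)N(C)C`, has not yet been measured. It differs from compound 2 in one place: a group of 11 heavy atoms (7 carbon, 2 nitrogen, 2 oxygen; one five-membered non-aromatic ring with 1 hetero atom) in place of a group of 10 heavy atoms (7 carbon, 2 nitrogen, 1 sulfur; one five-membered non-aromatic ring with 1 hetero atom), on a carbonyl carbon. Going by the values given here, the only measured step that bears on this place is the one from compound 1 to compound 2, which also alters the group on that carbonyl carbon and moves the number by a large amount. The data therefore show that this carbon position is sensitive, but they give no direct guide to the present exchange, which changes both the atom double-bonded to the carbamoyl carbon and adds a ketone to the ring. Given that sensitivity, a step of moderate size upward is expected, a 4.7-fold higher number from compound 2 to compound 3 (0.67 log units; beyond the scatter), with wide uncertainty. Compound 3 is estimated at 15 nM, between 3 nM and 80 nM.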

Compound 3, half-maximal effective concentration: 27 nM
The estimate for compound 3 lay 1.8-fold (0.26 log units) below the measured number; measured number inside the range.
By their numbers in this assay, from the lowest: compound 2; then compound 3; then compound 1.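

In this assay, the step of an 8.4-fold higher number from compound 2 to compound 3 (0.93 log units; beyond the scatter) shows that this carbonyl carbon tolerates 2-(dimethylcarbamoyl)-4-oxopyrrolidin-1-yl, although the number rises beyond the scatter and compound 2 remains the lower of the pair. The step of a 14-fold lower number from compound 1 to compound 3 (1.16 log units; beyond the scatter) shows that the large fall seen earlier at this place is not confined to the sulfur-bearing group of compound 2, as 2-(dimethylcarbamoyl)-4-oxopyrrolidin-1-yl in place of 2-(tert-butoxycarbonyl)pyrrolidin-1-yl also lowers the number by a large amount. Nothing available accounts for either step, and no measurement gives a reason for the order of the three compounds.

From the compounds shown here alone, the exchange from compound 2 to compound 3 changes sulfur to oxygen and adds the ketone to the ring in a single move, so how much of the rise belongs to each change remains open. Also open, going by these compounds, is how a hydroxyl group in place of that ketone, or a carboxylic acid in place of the dimethylcarbamoyl group, would read in this assay on the same shared core.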